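Shrinking a Ring Substituent Down to Methyl

The source may hold more compounds than are shown below. What is called first, only, known or untested is meant among the compounds shown, and "the series" means these compounds.

In an assay on isolated protein for inhibition of cathepsin S (Homo sapiens) (on this read-out higher numbers stand for weaker inhibition and lower numbers for stronger inhibition), compound 1 `N#C[C@@]1(NC(=O)[C@@H](CC(=O)N2CCOCC2)CC2CCCCC2)CCN(C2CCCC2)C1` gives 75 nM, while compound 2 `N#C[C@@]1(NC(=O)[C@@H](CC(=O)N2CCOCC2)CC2CCCCC2)CCN(C2CCCCC2)C1` gives 23 nM, the lower of the two numbers; the step of a 3.3-fold lower number from compound 1 to compound 2 (0.51 log units; beyond the scatter) lies beyond the scatter. Compound 3 `CN1CC[C@@](C#N)(NC(=O)[C@@H](CC(=O)N2CCOCC2)CC2CCCCC2)C1` differs from compound 2 by methyl in place of cyclohexyl on an amine nitrogen in a ring. Going by the values given here, the only measured step that bears on this change is a 3.3-fold lower number from compound 1 to compound 2 (0.51 log units; beyond the scatter), where the larger ring brought the lower number. Moving to a far smaller group, the step to compound 3 is therefore expected to raise the number, roughly a 13-fold higher number from compound 2 to compound 3 (1.12 log units; beyond the scatter). Compound 3 is thus estimated at 300 nM, within 80 nM to 1500 nM.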

Compound 3, half-maximal inhibitory concentration: 155 nM
For compound 3 the middle estimate is 1.9-fold (0.29 log units) above the measured one; measured number inside the range.
By their numbers in this assay, from the lowest: compound 2; then compound 1; then compound 3.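

With methyl in place of cyclohexyl on this amine nitrogen, a 6.7-fold higher number from compound 2 to compound 3 (0.83 log units; beyond the scatter) appears in this assay, so this change extends the comparison beyond two carbon rings. Methyl in place of cyclopentyl gives a 2.1-fold higher number from compound 1 to compound 3 (0.32 log units; beyond the scatter) as well, and across these three compounds the number falls as the group goes from methyl through cyclopentyl to cyclohexyl, with none going against that order. Nothing given here explains this order. Going by these compounds, whether an open chain such as isopropyl or a larger ring such as cycloheptyl would fit the same order remains open.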